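Hydroxy added to a weak monoamine oxidase A inhibitor

The source may hold more compounds than are shown below. What is called first, only, known or untested is meant among the compounds shown, and "the series" means these compounds.

The measured compounds:
compound 1 `COc1ccccc1/C=C1\SC(=O)N(CCN)C1=O` with 29900 nM
compound 2 `O=C1NC(=S)S/C1=C/c1ccncc1` with 21800 nM
compound 3 `Cc1cc(C)cc(CC2SC(=O)NC2=O)c1` with 50500 nM

All three were tested in an assay on isolated protein for inhibition of Amine oxidase [flavin-containing] A (Homo sapiens), read by fluorescence (on this read-out higher numbers stand for weaker inhibition and lower numbers for stronger inhibition), and all three inhibit only weakly. Compound 3 has the highest of the three numbers. Its gap to compound 1 lies within the scatter of repeated measurements, so the two cannot be told apart; its gap to compound 2 lies beyond it, so compound 2 inhibits somewhat more strongly than compound 3.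

Compound 4 `Cc1cc(CC2SC(=O)NC2=O)cc(C)c1O` differs from compound 3 in one place: hydroxy in place of hydrogen on an aromatic carbon. Within the data shown here, no pair among the measured compounds shows what such a change does here, so there is no step to lean on. The expectation is therefore a step of no more than the usual scatter, with a slight lean toward a lower number, as expressed by a 1.3-fold lower number from compound 3 to compound 4 (0.10 log units; within the scatter). For compound 4 the estimated value in this assay is 40000 nM, with a range from 15000 nM to 120000 nM.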

Compound 4, half-maximal inhibitory concentration: 26200 nM
Beside the measured number, compound 4's estimate is 1.5-fold (0.18 log units) above it, and the stated range covers the measured number.
By their numbers in this assay, from the lowest: compounds 2, 4, 1 and 3 (each within the scatter of the next, the first and the last beyond it).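

In this assay, among these compounds, hydroxy in place of hydrogen, on the aromatic carbon ortho to two methyl groups and para to a group of 8 heavy atoms, gives a 1.9-fold lower number from compound 3 to compound 4 (0.28 log units; within the scatter) and so offers the first direct reading of a change at this position. Since the step lies within the scatter, compound 3 and compound 4 cannot be told apart. This position therefore takes a hydroxy with no loss of inhibition that can be detected, while no gain can be claimed either.

As far as these compounds go, whether an amine or a carboxylic acid on this same aromatic carbon would move the number beyond the scatter remains open, as does whether hydroxy would behave alike with the two methyl groups absent. No measurement at hand explains the size of this step.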